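The source may hold more compounds than are shown below. What is called first, only, known or untested is meant among the compounds shown, and "the series" means these compounds.

Three compounds have been measured so far:

Compound 1, `CC(=O)OC/C(=C\c1ccccc1F)C(=O)c1ccccc1`, gives 5800 nM in a functional assay on NB-4 cells (Homo sapiens) for inhibition, read by XTT assay, with a stated time of 48 h; on this read-out lower numbers stand for stronger inhibition and higher numbers for weaker inhibition.
Compound 2, `COc1ccc(C(=O)/C(=C/c2ccccc2F)COC(C)=O)cc1`, gives 8200 nM in this assay.
Compound 3, `C=C(C(=O)c1ccc(OC)cc1)C(OC(C)=O)c1ccc([N+](=O)[O-])cc1`, gives 10300 nM in this assay.

Compound 1 and compound 2 differ in one place only: methoxy in place of hydrogen on an aromatic carbon. This change made a step of a 1.4-fold higher number from compound 1 to compound 2 (0.15 log units; within the scatter), so the two numbers cannot be told apart with confidence.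

Compound 3 belongs to a different core; the difference between the core of compound 3 and the core of compound 1 is not broken down here. Its value sits close to those of compound 1 and compound 2, and none of the three can be called stronger or weaker than the others.

Compound 4, `C=C(C(=O)c1ccc(OC)cc1OC)C(OC(C)=O)c1ccc([N+](=O)[O-])cc1`, has not yet been measured. It differs from compound 3 in one place: methoxy in place of hydrogen on an aromatic carbon. For the measured compounds named here, this is the same kind of change as the one between compound 1 and compound 2, but the surroundings differ. In compound 2 the entering methoxy sits para to a large group, whereas in compound 4 it sits ortho to a large group and meta to a methoxy group.

Since the change from compound 1 to compound 2 moved the number by only a 1.4-fold higher number from compound 1 to compound 2 (0.15 log units; within the scatter), a similarly small step is expected for compound 4 in this assay, roughly a 1.2-fold higher number from compound 3 to compound 4 (0.07 log units; within the scatter). For compound 4 the estimated value is 12000 nM, expected to fall between 5000 nM and 30000 nM.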

Compound 4, half-maximal inhibitory concentration: 5000 nM
Compound 4: middle estimate off by 2.4-fold (0.38 log units), on the high side; the measured number falls inside the stated range.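

On the core of compound 3, methoxy in place of hydrogen on an aromatic carbon gives a 2.1-fold lower number from compound 3 to compound 4 (0.31 log units; beyond the scatter) in this assay. This is a modest move towards stronger inhibition, whereas the same kind of change on the core of compound 1 gave a step within the scatter. The size of this change therefore does not carry over unaltered from one core to the other in this series: the same change on two cores in this assay, a 1.4-fold higher number (0.15 log units; within the scatter) from compound 1 to compound 2 and a 2.1-fold lower number (0.31 log units; beyond the scatter) from compound 3 to compound 4, 2.9-fold (0.46 log units) apart, beyond the scatter of two such steps. This does not show why the two steps differ, and it is no general rule, as it rests on just one pair of compounds per core; the cores differ, and the entering methoxy also sits in a different place, ortho to a large group and meta to a methoxy group in compound 4.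

The compounds shown leave open whether methoxy placed in that same position on the core of compound 1 would give a step like the one seen on the core of compound 3. They also leave open whether another group in that position, such as an ethoxy group, a hydroxyl group or an amine, would move the number in the same direction as methoxy does.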